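The source may hold more compounds than are shown below. What is called first, only, known or untested is meant among the compounds shown, and "the series" means these compounds.

Measured so far:
compound 1 `CC(C)c1ccc(-c2nc(SCc3cn(CC(=O)NC(=O)Nc4ccccn4)nn3)nc(Nc3ccccc3Cl)c2C#N)cc1`: 23400 nM
compound 2 `CC(C)c1ccc(-c2nc(SCc3cn(CC(=O)NC(=O)Nc4ccccn4)nn3)nc(Nc3cccc(C(F)(F)F)c3)c2C#N)cc1`: 24200 nM

Within the data shown here, in a functional assay on ECa-109 cells (Homo sapiens) for inhibition, read by MTT assay, with a stated time of 72 h (on this read-out lower numbers stand for stronger inhibition and higher numbers for weaker inhibition), compound 2 gives 24200 nM, the higher of the two numbers so far, with compound 1 the nearest at a 1.0-fold higher number from compound 1 to compound 2 (0.01 log units; within the scatter), so the two stand together. That single step changed the group on the nitrogen, not the aryl group that is now varied. Compound 3 `COc1cc(-c2nc(SCc3cn(CC(=O)NC(=O)Nc4ccccn4)nn3)nc(Nc3cccc(C(F)(F)F)c3)c2C#N)cc(OC)c1OC` is the next member: 3,4,5-trimethoxyphenyl in place of 4-isopropylphenyl on an aromatic carbon. Among the measured compounds shown here, no measured step touches this position, so nothing here shows how far the number may move; the one known step, on another site, stayed within the scatter. The step of a 1.3-fold lower number from compound 2 to compound 3 (0.13 log units; within the scatter) is therefore expected to be small, with wide uncertainty in either direction. For compound 3 in this assay the estimate is 18000 nM, ranging from 5000 nM to 60000 nM.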

Compound 3, half-maximal inhibitory concentration: > 64000 nM
Compound 3: no number, only a limit; the forecaster's own chance of this, stated with the estimate: 10%; middle value at least 3.5-fold (0.55 log units) from the limit.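

In this assay compound 3 gives > 64000 nM, which is a limit of the assay and not a number. This position, on an aromatic carbon ortho to a cyano group, does respond: 3,4,5-trimethoxyphenyl in place of 4-isopropylphenyl gives an at least 2.6-fold higher number from compound 2 to compound 3 (0.42 log units; beyond the scatter), whereas the earlier step on the nitrogen substituent gave a 1.0-fold higher number from compound 1 to compound 2 (0.01 log units; within the scatter). Only the direction, towards weaker inhibition, and a minimum size can be read from this step: the limit of > 64000 nM in this assay, at which 1 of the 3 values shown sits.

As far as these compounds go, whether the weakening belongs to the three methoxy groups together, to one of them, or to the loss of the isopropyl group stays open, as does the reading of a 4-methoxyphenyl or 4-(dimethylamino)phenyl group here. Also open, from the compounds shown here alone, is whether the same change would read alike with 2-chlorophenyl on the nitrogen.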